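A few compounds are considered here, and "the series" means these few. Any claim that something is new, unique, unknown or untested is made for them only; others in the source may bear on it.

Compound 1 `ClCc1ccccc1Cn1cnc2c(Cl)nc(Cl)nc21` is the least tolerated of the three compounds measured: in a functional assay on OVCAR-3 cells (Homo sapiens) for cytotoxicity, read by sulforhodamine B assay, with a stated time of 48 h (a lower number here means that less compound is tolerated, a higher number that more compound is tolerated), compound 1 gives 1540 nM. Compound 2 `ClCc1cccc(Cn2cnc3c(Cl)ncnc32)c1` gives 5750 nM in this assay, and compound 3 `ClCc1ccc(Cn2cnc3c(Cl)nc(Cl)nc32)cc1` gives 9550 nM; both gaps from compound 1 lie beyond the scatter, so compound 1 stands clearly lowest. Compound 4 `Nc1nc(Cl)c2ncn(Cc3ccccc3CCl)c2n1` has not yet been measured. It differs from compound 1 in a single place, (amino in place of chloro on an aromatic carbon), the amino sitting between two ring nitrogen atoms of the shared core. Among the measured compounds shown here, no measured pair shows this exchange, so its size is unknown. A modest step towards a higher number is expected, a 1.9-fold higher number from compound 1 to compound 4 (0.29 log units; within the scatter), though a result within the scatter would not surprise. Compound 4 is estimated at 3000 nM, with a range from 800 nM to 12000 nM.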

Compound 4, concentration lethal to 50% of the cells: 46800 nM
Beside the measured number, compound 4's estimate is 16-fold (1.19 log units) below it; measured number above the stated range.
By their numbers in this assay, from the lowest: compound 1; then compounds 2 and 3 (each within the scatter of the next); then compound 4.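

On the aromatic carbon between two ring nitrogen atoms, amino in place of chloro gives a 30-fold higher number from compound 1 to compound 4 (1.48 log units; beyond the scatter) in this assay, so far more compound is tolerated. The earlier compounds shown here offered no clean view of this position, and this exchange of one heavy atom shows that it strongly affects the result. Nothing available here accounts for the size of this step. Still open, on these data alone, is whether a methoxy or a dimethylamino group on this carbon would move the number as far. Also open, as far as these compounds go, is whether the same exchange would have a similar effect with the chloromethyl group elsewhere on the benzene ring.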